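Swapping Trifluoromethyl for Ethyl on Compound 3

The source may hold more compounds than are shown below. What is called first, only, known or untested is meant among the compounds shown, and "the series" means these compounds.

Of the compounds shown here, three have been measured in an assay on Jurkat cells for inhibition of nuclear factor NF-kappa-B complex (Homo sapiens), read by a luciferase reporter; on this read-out higher numbers stand for weaker inhibition and lower numbers for stronger inhibition. Compound 1 `Cc1nc(Cl)ncc1C(=O)Nc1cc(Cl)cc(Cl)c1` gives 500 nM in this assay. Compound 2 `O=C1c2cnc(Cl)nc2C(=O)N1c1cc(C(F)(F)F)cc(C(F)(F)F)c1` gives 13000 nM in this assay. Compound 3 `CCOC(=O)c1cnc(NN2C(=O)C=C(C)C2=O)nc1C(F)(F)F` gives 2000 nM in this assay, which puts compound 3 second highest of the three numbers: the number for compound 1 is lower by a margin beyond the usual scatter, and the number for compound 2 is higher by a margin that is also beyond the scatter.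

Compound 4 `CCOC(=O)c1cnc(NN2C(=O)C=C(C)C2=O)nc1CC` differs from compound 3 in one place: ethyl in place of trifluoromethyl on an aromatic carbon. Going by the values given here, no measured pair of compounds shows this change, so there is nothing in these data to say which way it moves the read-out. The expected step is therefore small, likely within the scatter, with the direction left open: in this assay the step from compound 3 to compound 4 is expected to be a 1.3-fold higher number from compound 3 to compound 4 (0.10 log units; within the scatter). Compound 4 is expected to give about 2500 nM in this assay, within a range from 800 nM to 8000 nM.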

Compound 4, half-maximal inhibitory concentration: 400 nM
Estimate against measurement, compound 4: 6.3-fold (0.80 log units) above, outside the stated range (below it).
By their numbers in this assay, from the lowest: compounds 4 and 1 (each within the scatter of the next); then compound 3; then compound 2.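

The first pair differing in one place shows that the read-out is sensitive to the group on this aromatic carbon, next to the ring nitrogen and ortho to an ethoxycarbonyl group: in this assay, ethyl in place of trifluoromethyl gives a 5.0-fold lower number from compound 3 to compound 4 (0.70 log units; beyond the scatter). Here the lower number comes with ethyl, of 2 heavy atoms, replacing trifluoromethyl, of 4, though one pair cannot show whether that count matters. Nothing available explains this step.

As far as these compounds go, whether the lower number is particular to ethyl or extends to other groups at this carbon, such as a longer chain like propyl or an amine, remains open. Also open, from the compounds shown here alone, is whether the step would hold with a carboxylic acid in place of the ethoxycarbonyl group.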